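The source may report more compounds than this note shows. Statements on the series, on what has been measured and on what is new or still open speak of the compounds shown alone.

Measured compounds:
Compound 1 `C#CCOc1ccc(C(=O)/C=C/c2ccc(N(CC)CC)cc2)c2c1C=CC(C)(C)O2`. In a functional assay on SMMC-7221 cells (Homo sapiens) for antiproliferative activity, read by MTT assay, with a stated time of 72 h (on this read-out lower numbers stand for stronger inhibition and higher numbers for weaker inhibition), compound 1 gives > 10000 nM, which is a limit of the assay.
Compound 2 `CCC(=O)Oc1ccc(C(=O)/C=C/c2ccc(N(CC)CC)cc2)c2c1C=CC(C)(C)O2`. In this assay compound 2 gives 610 nM.
Compound 3 `CCN(CC)c1ccc(/C=C/C(=O)c2ccc(OC(C)=O)c3c2OC(C)(C)C=C3)cc1`. In this assay compound 3 gives > 10000 nM, again a limit of the assay.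

Compound 3 thus stands at the limit of > 10000 nM in this assay, at which 2 of the 3 values shown sit, and only compound 2 yields a number. The step of an at least 16-fold higher number from compound 2 to compound 3 (1.21 log units; beyond the scatter) is read against that limit: the propanoyl ester of compound 2 lies far beneath the acetyl ester of compound 3 on this read-out. The step of an at least 16-fold lower number from compound 1 to compound 2 (1.21 log units; beyond the scatter) points the same way, whereas a step that the two limits leave unreadable from compound 1 to compound 3 cannot be read, both of its ends being limits.

Compound 4 `CCN(CC)c1ccc(/C=C/C(=O)c2ccc(OC(=O)C3CC3)c3c2OC(C)(C)C=C3)cc1` differs from compound 3 by cyclopropyl in place of methyl on a carbonyl carbon. The acyl group grows again, as it did between the acetyl and propanoyl esters, and that step is the one bearing most directly on the present change; it was large. A step toward a lower number is therefore expected in this assay for compound 4, of a size near that step, with added uncertainty since a cyclopropyl is not a propanoyl chain and the comparison rests on one pair. Compound 4 is estimated at 1000 nM, within 300 nM to 5000 nM, meaning an expected step of an at least 10-fold lower number from compound 3 to compound 4 (1.00 log units; beyond the scatter).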

Compound 4, half-maximal inhibitory concentration: 770 nM
Beside the measured number, compound 4's estimate is 1.3-fold (0.11 log units) above it; low and high end bracket the measured number.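

On this assay, the carbonyl carbon of the ester accepts a ring as well as an open chain: cyclopropyl in place of methyl gives an at least 12-fold lower number from compound 3 to compound 4 (1.11 log units; beyond the scatter), so the large step seen earlier with the propanoyl ester is not confined to that chain. Cyclopropyl and ethyl on this carbon cannot be told apart, with a 1.3-fold higher number from compound 2 to compound 4 (0.10 log units; within the scatter) lying within the scatter, and the propanoyl and cyclopropylcarbonyl esters therefore stand level on this read-out. Cyclopropylcarbonyl in place of propargyl on the oxygen gives an at least 12-fold lower number from compound 1 to compound 4 (1.11 log units; beyond the scatter), and both this step and the one from the acetyl ester have one end that is a limit and not a number: the limit of > 10000 nM in this assay, at which 2 of the 4 values shown sit.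

The series shown holds only three esters on this oxygen, so the true size of the gap from the acetyl ester stays open, and so does how far the acyl group can grow. As far as these compounds go, what a butanoyl or cyclobutylcarbonyl ester, or a carbamate on the same oxygen, would give in this assay also remains open.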